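The source may hold more compounds than are shown below. What is called first, only, known or untested is meant among the compounds shown, and "the series" means these compounds.

In an in vitro ADME assay on microsomes from liver (Mus musculus) for pharmacokinetics, read by LC-MS, with a stated time of 10 min, tested at 1 uM (a higher number here means faster removal of the compound, a lower number slower removal), compound 1 `COc1cccc(NC(=O)[C@H]2CN(C)C[C@@H]2c2ccc(/C=C/C(=O)Nc3ccccc3N)cc2)c1` gives 65 mL/min/kg and compound 2 `Cc1cc(NC(=O)[C@H]2CN(C)C[C@@H]2c2ccc(/C=C/C(=O)Nc3ccccc3N)cc2)ccc1Cl` gives 65 mL/min/kg, so compound 2 stands level with compound 1. Compound 3 `CN1C[C@H](C(=O)Nc2ccc(Cl)cc2F)[C@@H](c2ccc(/C=C/C(=O)Nc3ccccc3N)cc2)C1` differs from compound 2 as follows: 4-chloro-2-fluorophenyl in place of 4-chloro-3-methylphenyl on an amide-type nitrogen. Among the measured compounds shown here, the one measured step that bears on this also exchanges the group on an amide-type nitrogen, and it reads no change at the digits printed from compound 1 to compound 2 (within the scatter). On that single step, no shift beyond the scatter is expected in this assay, and the expected step is a 1.1-fold lower number from compound 2 to compound 3 (0.03 log units; within the scatter). For compound 3 the estimated clearance is 60 mL/min/kg, with an expected range of 35 mL/min/kg to 100 mL/min/kg.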

Compound 3, clearance: 43 mL/min/kg
Estimate against measurement, compound 3: 1.4-fold (0.14 log units) above, and the stated range covers the measured number.
By their numbers in this assay, from the lowest: compounds 3, 1 and 2 (each within the scatter of the next).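

In this assay a third substituted phenyl group on the amide-type nitrogen, 4-chloro-2-fluorophenyl, gives a 1.5-fold lower number from compound 2 to compound 3 (0.18 log units; within the scatter) and also a 1.5-fold lower number from compound 1 to compound 3 (0.18 log units; within the scatter). The position has now taken a fluorine-bearing group as well, and all three groups shown remain within the scatter of one another. Nothing here gives a reason for these readings. On these data alone, whether an amine, a carboxylic acid or a cyclohexyl group on this nitrogen would move clearance beyond the scatter stays open.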